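Chloro for fluoro with no measured partner

The source may hold more compounds than are shown below. What is called first, only, known or untested is meant among the compounds shown, and "the series" means these compounds.

In an ADME assay on J774.A1 cells (Mus musculus) for cytotoxicity, read by MTT assay, with a stated time of 48 h (a higher number here means that more compound is tolerated, a lower number that less compound is tolerated), compound 1 `COC(=O)c1c(NCc2ccccc2)noc1-c1ccc([N+](=O)[O-])cc1` gives 85400 nM as its half-maximal cytotoxic concentration. For compound 2 `COC(=O)c1c(NCc2ccc(F)cc2)noc1-c1ccc([N+](=O)[O-])cc1` the entry reads "not determined" (no result reported) and so compound 2 offers no number to start from. Next comes compound 3 `COC(=O)c1c(NCc2ccc(Cl)cc2)noc1-c1ccc([N+](=O)[O-])cc1` with a single change: chloro in place of fluoro on an aromatic carbon which puts chloro in place of fluoro on an aromatic carbon, para to a large group. Among the measured compounds shown here, no measured pair in this small set shows what such a swap does. The expectation in this assay is therefore no step beyond the usual scatter, with neither direction favoured. For the measured compounds named here, the only number to lean on is that of compound 1 at 85400 nM and the estimate stays close to it. Compound 3 is expected at 80000 nM with an estimated range of 35000 nM to 180000 nM in this measurement.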

Compound 3, half-maximal cytotoxic concentration: 78300 nM
For compound 3 the middle estimate is 1.0-fold (0.01 log units) above the measured one; the measured number falls inside the stated range.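

In this assay the change to chloro in place of hydrogen on this aromatic carbon gives a 1.1-fold lower number from compound 1 to compound 3 (0.04 log units; within the scatter) and so cannot be told apart from no change at all. Among the compounds shown here, this is the first readable result for a substituent at this position, and it shows that one chloro atom there leaves the cell tolerance of the series where compound 1 had it. The swap of chloro for fluoro itself cannot be read, as compound 2 has no number, and nothing measured here offers an explanation for the result.

As far as these compounds go, whether an amine, a methoxy group or a carboxylic acid on the same carbon would also leave the number in place remains open. Also open, from the compounds shown here alone, is whether a carboxylic acid in place of the methyl ester would shift it.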